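Swapping One Halogenated Phenyl Ring on a Cytotoxicity Read-Out

The compounds below may be only part of what the source reports. "The series", "measured", "known", "first", "only" and "open" are said of these compounds alone.

Measured so far:
Compound 1, `Cn1c(-c2cccc(F)c2)cnc1NC(=O)c1ccc(F)cc1`: in a toxicity assay on THP-1 cells (Homo sapiens) for inhibition (on this read-out higher numbers stand for lower toxicity in this test and lower numbers for higher toxicity in this test), compound 1 gives 58000 nM.
Compound 2, `COc1ccc(-c2cnc(NC(=O)c3ccccc3OC)n2C)cc1`: in this assay compound 2 gives only a limit, > 100000 nM.

Going by the values given here, compound 1 therefore stands as the only real number in this assay; the other value is a limit, (the limit of > 100000 nM in this assay, at which 1 of the 2 values shown sits). Compound 2 differs from compound 1 in more than one place. Among the compounds with values here, no single step between measured compounds can be read from these two values.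

Compound 3, `Cn1c(-c2ccccc2Cl)cnc1NC(=O)c1ccc(F)cc1`, is not yet measured. It differs from compound 1 by 2-chlorophenyl in place of 3-fluorophenyl on an aromatic carbon. Within the data shown here, with no measured step to lean on, the expectation for compound 3 is a step from compound 1 of a 1.2-fold lower number from compound 1 to compound 3 (0.06 log units; within the scatter), which lies within the usual scatter of this assay in either direction. Compound 3 is estimated at 50000 nM, with a range from 20000 nM to 120000 nM.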

Compound 3, half-maximal cytotoxic concentration: > 50000 nM
Compound 3: a limit, no number; the forecaster's own chance of this, stated with the estimate: 25%; the middle value lies on the limit itself.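

Going by these compounds alone, no step from compound 1 to compound 3 can be read: compound 3 gives only the limit > 50000 nM and not a number. The compounds shown leave open whether 2-chlorophenyl in place of 3-fluorophenyl on the shared core changes the half-maximal cytotoxic concentration at all, or in which direction.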